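This account rests on a few compounds, and the source may have more. Where it says the series, first, only, none or still open, it means among the compounds named here.

Compound 1 `CC(C)=CCC[C@@](C)(/C=C/c1ccccc1)/C=C/c1ccc(O)cc1`, compound 2 `CC(C)=CCC[C@](C)(/C=C/c1ccc(O)cc1)/C=C/c1cccc(F)c1` and compound 3 `C=C[C@@](C)(/C=C/c1ccc(Nc2ccc(F)cc2)cc1)CCC=C(C)C` were tested in an ADME assay on BJ cells (Homo sapiens) for cytotoxicity, with a stated time of 72 h; on this read-out lower numbers stand for an effect already at smaller amounts and higher numbers for an effect only at larger amounts of compound. The difference between the core of compound 1 and that of compound 3 is not broken down here. In this assay compound 1 gives only a limit of > 36600 nM. Compound 2 likewise gives only a limit of > 36600 nM. Compound 3 too gives only a limit of > 36600 nM. The change from compound 1 to compound 2 is fluoro in place of hydrogen on an aromatic carbon, and it makes a step that the two limits leave unreadable from compound 1 to compound 2, since (the limit of > 36600 nM in this assay, at which 3 of the 3 values shown sit). Compound 4 `C=C[C@@](C)(/C=C/c1ccc(Nc2ccc(F)c(F)c2)cc1)CCC=C(C)C` is not yet measured; it differs from compound 3 by fluoro in place of hydrogen on an aromatic carbon, the same kind of change, here ortho to a fluoro group. Because (the limit of > 36600 nM in this assay, at which 3 of the 3 values shown sit), the step from compound 3 to compound 4 is expected to be a step that the limit leaves unreadable from compound 3 to compound 4. Compound 4 is estimated at 45000 nM, between 20000 nM and 100000 nM.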

Compound 4, half-maximal effective concentration: > 36600 nM
Compound 4 ended at the assay's limit (the forecaster's own chance of this, stated with the estimate: 85%); the middle value does not contradict the limit.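

No new step can be read between compound 3 and compound 4, since both give only a limit: the limit of > 36600 nM in this assay, at which 4 of the 4 values shown sit.

The compounds shown leave open whether compound 3 and compound 4 differ at all in cytotoxicity, and where any half-maximal effect would lie.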